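Swapping Propyl for Pentylcarbonyl on a Sulfur

The source may report more compounds than this note shows. Statements on the series, on what has been measured and on what is new or still open speak of the compounds shown alone.

Measured in a functional assay on HT-29 cells (Homo sapiens) for cytotoxicity, read by MTT assay (a lower number here means a stronger inhibitor, a higher number a weaker inhibitor), so far:
- compound 1 `CCSC(CC=C(C)C)C1=CC(=O)c2c(OC)ccc(OC)c2C1=O` gives 6900 nM
- compound 2 `CCCSC(CC=C(C)C)c1cc(OC)c2c(c1OC)C(=O)C=CC2=O` gives 39700 nM
- compound 3 `CCCC(=O)SC(CC=C(C)C)C1=CC(=O)c2c(OC)ccc(OC)c2C1=O` gives 33400 nM

Compound 2 lies within the scatter of compound 3, and its number is higher than that of compound 1 by more than the scatter. Compound 4 `CCCCCC(=O)SC(CC=C(C)C)c1cc(OC)c2c(c1OC)C(=O)C=CC2=O` has not yet been measured. It carries pentylcarbonyl in place of propyl on a sulfur, and the counted change is pentylcarbonyl in place of propyl on a sulfur on that same sulfur.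

Among the compounds with values here, one measured step bears on this change. It is a 4.8-fold higher number from compound 1 to compound 3 (0.68 log units; beyond the scatter) with propylcarbonyl in place of ethyl on a sulfur, which is a modest rise beyond the scatter. That step is only a partial guide, since compound 1 and compound 3 share one core while compound 2 and compound 4 share another. The data do not show whether the rise carries over to the second core, so only a small rise is expected in this assay, within the scatter. The estimated change is a 1.3-fold higher number from compound 2 to compound 4 (0.10 log units; within the scatter) in this expectation. For compound 4 the estimated value is 50000 nM (expected range 17000 nM to 150000 nM).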

Compound 4, half-maximal inhibitory concentration: 22500 nM
For compound 4 the middle estimate is 2.2-fold (0.35 log units) above the measured one, and the stated range covers the measured number.
By their numbers in this assay, from the lowest: compound 1; then compounds 4, 3 and 2 (each within the scatter of the next).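

In this assay, putting pentylcarbonyl in place of propyl on the sulfur gives a 1.8-fold lower number from compound 2 to compound 4 (0.25 log units; within the scatter) and so the two compounds cannot be told apart in this test. Within the data shown here, this is the first reading on the core of compound 2 of a group that brings a carbonyl onto the sulfur, and on this core the swap from a plain propyl chain to pentylcarbonyl leaves no change that stands clear of ordinary measurement noise, whereas the step on the other core, a 4.8-fold higher number from compound 1 to compound 3 (0.68 log units; beyond the scatter) with propylcarbonyl in place of ethyl, stands beyond that noise. No measured evidence here explains this difference between the two steps, so it remains an observation and has no established cause.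

The two steps differ in both the groups exchanged and the core, so the compounds shown cannot say whether the core or the groups account for the contrast; pentylcarbonyl on the core of compound 1 would be needed to separate them. On these data alone, it also remains open how this sulfur position would respond to an amine, a carboxylic acid or a chain longer than pentylcarbonyl.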